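The source may report more compounds than this note shows. Statements on the series, on what has been measured and on what is new or still open speak of the compounds shown alone.

Three compounds of the series have a number in an assay for inhibition of Apoptosis regulator Bcl-2 (Homo sapiens), read by fluorescence polarization, with a stated time of 2 h; a lower number here means a stronger inhibitor, a higher number a weaker inhibitor. Compound 1 `CCCn1c(C)c(C(=O)O)c(-c2cccc(N3CCN(c4ccc(NS(=O)(=O)c5ccc(N[C@H](CCN6CCC(O)CC6)CSc6ccccc6)c(S(=O)(=O)C(F)(F)F)c5)cc4)CC3)c2)c1-c1ccc(Cl)cc1` gives 30.1 nM, compound 2 `Cc1c(C(=O)O)c(-c2cccc(N3CCN(c4ccc(NS(=O)(=O)c5ccc(N[C@H](CCN6CCC(O)CC6)CSc6ccccc6)c(S(=O)(=O)C(F)(F)F)c5)cc4)CC3)c2)c(-c2ccc(Cl)cc2)n1C` gives 10.2 nM, and compound 3 `Cc1c(C(=O)NCCCN2CCN(C)CC2)c(-c2cccc(N3CCN(c4ccc(NS(=O)(=O)c5cccc(S(=O)(=O)C6CC6)c5)cc4)CC3)c2)c(-c2ccc(Cl)cc2)n1C` gives 844 nM, the highest of the three numbers; compound 1 is the nearest of the others and compound 2 the furthest, both gaps beyond the scatter. Compound 4 `Cc1c(C(=O)NCCCN2CCN(C)CC2)c(-c2cccc(N3CCN(c4ccc(NS(=O)(=O)c5cccc(OC(C)C)c5)cc4)CC3)c2)c(-c2ccc(Cl)cc2)n1C` differs from compound 3 in one place: isopropoxy in place of cyclopropylsulfonyl on an aromatic carbon. Among the measured compounds shown here, no measured pair carries this same change, so nothing here fixes the size of the step. The expected step from compound 3 to compound 4 in this assay is a 1.3-fold higher number from compound 3 to compound 4 (0.12 log units; within the scatter), a small move that may not exceed the scatter. Compound 4 is estimated at 1100 nM in this assay, with a range of 300 nM to 4000 nM.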

Compound 4, half-maximal inhibitory concentration: 2020 nM
Beside the measured number, compound 4's estimate is 1.8-fold (0.26 log units) below it; the range from low to high includes it.
By their numbers in this assay, from the lowest: compound 2; then compound 1; then compound 3; then compound 4.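

In this assay, among the compounds shown here, isopropoxy in place of cyclopropylsulfonyl gives a 2.4-fold higher number from compound 3 to compound 4 (0.38 log units; beyond the scatter) and this is the first single-place step, modest in size. This aromatic carbon, meta to a large group, therefore responds to the change, while compound 4 still keeps a measurable number at 2020 nM in this assay. No available evidence ties the step to any feature of either group.

As far as these compounds go, whether a nitrile or a primary amide on this aromatic carbon would give a lower or higher number stays open. Also open, from the compounds shown here alone, is whether the same change gives a step of similar size on another core.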